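The source may hold more compounds than are shown below. What is called first, only, known or untested is meant among the compounds shown, and "the series" means these compounds.

Measured in a physicochemical assay for lipophilicity, measured as octanol-water partition; a higher number here means a more lipophilic compound, a lower number a more polar compound:
- compound 1 `Cc1ccc(/C=N/c2ccccc2C(=O)NNc2ccnc3cc(Cl)ccc23)cc1`: 5.31
- compound 2 `COc1ccc(/C=N/c2ccccc2C(=O)NNc2ccnc3cc(Cl)ccc23)cc1`: 5
- compound 3 `O=C(NNc1ccnc2cc(Cl)ccc12)c1ccccc1/N=C/c1ccc([N+](=O)[O-])cc1`: 4.58

Compound 3, at 4.58, is the lowest of the three, and compound 2 is its nearest neighbour. Compound 4 `O=C(NNc1ccnc2cc(Cl)ccc12)c1ccccc1/N=C/C=C/c1ccccc1` has not been measured. It carries 2-phenylethenyl in place of 4-nitrophenyl on a carbon with a double bond to nitrogen.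

For the measured compounds named here, no measured step makes this exact change, so the evidence is indirect. The closest comparisons are those in which nitro enters on the aromatic ring: a number 0.73 log units lower from compound 1 to compound 3 (beyond the scatter) and a number 0.42 log units lower from compound 2 to compound 3 (beyond the scatter). A smaller related step is a number 0.31 log units lower from compound 1 to compound 2 (beyond the scatter). Compound 4 has no nitro, and the same is true of compound 1 and compound 2, so a modest rise in this assay is expected, beyond the scatter. Going by the values given here, the size of that rise remains uncertain, as no measured compound carries 2-phenylethenyl. The estimated step is a number 0.67 log units higher from compound 3 to compound 4 (beyond the scatter). For compound 4 the estimated value is 5.25, with an expected range from 4.8 to 5.7.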

Compound 4, partition coefficient: 5.54
Compound 4: middle estimate off by 0.29 log units, on the low side, within the range that was stated.
By their numbers in this assay, from the lowest: compound 3; then compound 2; then compounds 1 and 4 (each within the scatter of the next).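

In this assay, the carbon with a double bond to nitrogen now shows a change of the whole group rather than of a substituent on its phenyl ring: 2-phenylethenyl gives a number 0.96 log units higher from compound 3 to compound 4 (beyond the scatter) and a number 0.54 log units higher from compound 2 to compound 4 (beyond the scatter) in the comparisons with the nitro and methoxy compounds. Against 4-methylphenyl, the same group gives a number 0.23 log units higher from compound 1 to compound 4 (within the scatter) and so cannot be told apart from it in this read-out. No supporting measurement bears on why these steps take these sizes.

Still open, from the compounds shown here alone, is whether methyl, methoxy and nitro on the ring of 2-phenylethenyl would keep the order they show on the phenyl ring of compound 1, compound 2 and compound 3. Also open, going by these compounds, is how an amine or a carboxylic acid on that ring, or a saturated chain in place of the ethenyl link, would read in this assay at this position.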